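Aryl variation on the sulfonyl of the shared core

The source may hold more compounds than are shown below. What is called first, only, known or untested is meant among the compounds shown, and "the series" means these compounds.

In an assay on isolated protein for displacement of a labelled ligand from metabotropic glutamate receptor 5 (Homo sapiens), with a stated time of 60 min, tested at 1 uM (a higher number here means more inhibition at the concentration tested (going by the name of the read-out), a lower number less inhibition), compound 3 `CC1CCN(c2c(S(=O)(=O)c3cc(Cl)cc(Cl)c3)cnc3cc(Cl)ccc23)CC1` gives 93%. Among the three numbers so far compound 3 stands second highest; its nearest neighbour is compound 2 `Cc1ccc(S(=O)(=O)c2cnc3cc(Cl)ccc3c2N2CCC(C)CC2)cc1`, which gives 94%, with the step of a number 1 percentage points lower from compound 2 to compound 3 (within the scatter). Furthest away is compound 1 `CC1CCN(c2c(S(=O)(=O)c3ccc(C#N)cc3)cnc3cc(Cl)ccc23)CC1`, which gives 70%, the step being a number 23 percentage points higher from compound 1 to compound 3 (beyond the scatter).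

The change to compound 4 `COc1ccc(S(=O)(=O)c2cnc3cc(Cl)ccc3c2N2CCC(C)CC2)cc1` is 4-methoxyphenyl in place of 3,5-dichlorophenyl on a sulfonyl sulfur.

For the measured compounds named here, two measured steps bear on this change, both altering the aryl on the sulfonyl sulfur: a number 1 percentage points lower from compound 2 to compound 3 (within the scatter) and a number 23 percentage points higher from compound 1 to compound 3 (beyond the scatter). A third, a number 24 percentage points higher from compound 1 to compound 2 (beyond the scatter), alters only the substituent on that aryl and is of similar size to the second. The two aryl groups carrying methyl or chlorine sit together at the top, while the cyano-bearing aryl sits clearly lower; 4-methoxyphenyl has no direct comparator in the set, so its position between these is open. The step of a number 8 percentage points lower from compound 3 to compound 4 (within the scatter) is therefore expected to be small to modest and downward, with a real chance that it falls within the scatter.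

For compound 4 the expected value in this assay is 85%, with a range of 65% to 97%.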

Compound 4, a percentage reported as inhibition, at one concentration (the size of the read-out at that concentration, not a potency): 79%
For compound 4 the middle estimate is 6 percentage points above the measured one; the range from low to high includes it.
By their numbers in this assay, from the lowest: compounds 1 and 4 (each within the scatter of the next); then compounds 3 and 2 (each within the scatter of the next).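

In this assay, a phenyl on the sulfonyl sulfur with a single substituent at the same place does not by itself keep the number at the level of compound 2: swapping methyl for methoxy gives (a number 15 percentage points lower from compound 2 to compound 4 (beyond the scatter)), and replacing 3,5-dichlorophenyl with 4-methoxyphenyl gives a step of similar reading (a number 14 percentage points lower from compound 3 to compound 4 (beyond the scatter)). The drop seen earlier with the cyano-bearing aryl is therefore no longer unique to that group, since methoxy in place of cyano gives (a number 9 percentage points higher from compound 1 to compound 4 (within the scatter)), leaving compound 1 and compound 4 together as a lower pair, set apart from compound 2 and compound 3 as an upper pair. Nothing available on these compounds explains why methoxy and cyano read alike here.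

As far as these compounds go, whether this two-level split holds for other groups on the aryl, such as an amine, a carboxylic acid or a longer alkoxy chain, remains open. These are also readings at a single concentration with only the sulfonyl aryl varied, so the potencies of the upper pair and the effect of changes elsewhere on the shared core stay undefined.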